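This account rests on a few compounds, and the source may have more. Where it says the series, first, only, none or still open, it means among the compounds named here.

For the measured compounds named here, compound 3, with the structure `C=C(C)CN(C1=NCCN1)c1c(Br)cccc1Br`, is one of three compounds measured in a physicochemical assay for lipophilicity (a higher number here means a more lipophilic compound, a lower number a more polar compound), the others being compound 1 `CCCCN(C1=NCCN1)c1c(Br)cccc1Br` and compound 2 `CC(C)CN(C1=NCCN1)c1c(Br)cccc1Br`. Compound 1 gives -2.5 in this assay, compound 2 gives -0.64, and compound 3 gives -0.66. Compound 3 thus stands second highest of the three numbers, but its step to compound 2, a number 0.02 log units lower from compound 2 to compound 3 (within the scatter), is within the scatter, so no order between compound 2 and compound 3 can be read. The step of a number 1.84 log units higher from compound 1 to compound 3 (beyond the scatter) is large and beyond the scatter.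

The next compound, compound 4 `Brc1cccc(Br)c1N(Cc1ccccc1)C1=NCCN1`, differs from compound 3 in one place: phenyl in place of 1-methylethenyl on a saturated chain carbon bound to a nitrogen on an aromatic ring. Going by the values given here, no measured step swaps an open chain for phenyl, so none bears directly on this change. The steps of a number 1.86 log units higher from compound 1 to compound 2 (beyond the scatter) and a number 1.84 log units higher from compound 1 to compound 3 (beyond the scatter) show that a single change at this place can shift the read-out by a large amount, while a number 0.02 log units lower from compound 2 to compound 3 (within the scatter) shows that a small change there can leave it unmoved. A larger carbon group enters, so a step upward in this assay is expected for compound 4, of the size a number 1.06 log units higher from compound 3 to compound 4 (beyond the scatter). Compound 4 is therefore estimated at 0.4, within the range -0.6 to 1.4.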

Compound 4, distribution coefficient: -0.05
The estimate for compound 4 lay 0.45 log units above the measured number; the measured number falls inside the stated range.
By their numbers in this assay, from the lowest: compound 1; then compounds 3 and 2 (each within the scatter of the next); then compound 4.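

In this assay, phenyl at this place, on a saturated chain carbon bound to a nitrogen on an aromatic ring, separates compound 4 from both branched groups: the change gives a number 0.61 log units higher from compound 3 to compound 4 (beyond the scatter) and a number 0.59 log units higher from compound 2 to compound 4 (beyond the scatter), both modest, whereas 1-methylethenyl in place of isopropyl gave no readable shift. Against the propyl compound the change gives a number 2.45 log units higher from compound 1 to compound 4 (beyond the scatter), a large step, but much of that size is already present in a number 1.86 log units higher from compound 1 to compound 2 (beyond the scatter), so phenyl adds only a modest part beyond what the branched group gives. Nothing measured here accounts for these steps.

The compounds shown leave open whether the step belongs to the aromatic ring of phenyl or simply to the larger carbon group, which cyclohexyl in the same place would help to separate. They also leave open how far the number would move with a phenyl ring carrying a methoxy group or a chlorine, or with a pyridyl ring or a longer chain at this place.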